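Replacing a methylpyrazole with an indazole: clearance outlook

This account rests on a few compounds, and the source may have more. Where it says the series, first, only, none or still open, it means among the compounds named here.

Compound 1 `Nc1ccc(S(=O)(=O)N2CCN(c3ncc(C(O)(C(F)(F)F)C(F)(F)F)cc3C#CC3CC3)CC2)cn1` in an ADME assay (liver) for metabolic stability, with Liver microsome (Homo sapiens) as the target, using microsomes and NADPH, with a stated time of 30 min, tested at 1 uM (on this read-out lower numbers stand for slow clearance and higher numbers for fast clearance), gives < 14 mL.min-1.g-1, which is a limit of the assay.
Compound 2 `CC(C)(O)C#Cc1cc(C(O)(C(F)(F)F)C(F)(F)F)cnc1N1CCN(S(=O)(=O)c2ccc(N)nc2)CC1` gives < 14 mL.min-1.g-1, again a limit.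
Compound 3 `Cn1cc(-c2cc(C(O)(C(F)(F)F)C(F)(F)F)cnc2N2CCN(S(=O)(=O)c3ccc(N)nc3)CC2)cn1` gives 19 mL.min-1.g-1.

Compound 3 is the only one of the three with an actual number; the other two sit at the limit of < 14 mL.min-1.g-1 in this assay, at which 2 of the 3 values shown sit. The change from compound 1 to compound 3 was an at least 1.3-fold higher number from compound 1 to compound 3 (0.13 log units; that floor lies within the scatter), and from compound 2 to compound 3 it was an at least 1.3-fold higher number from compound 2 to compound 3 (0.13 log units; that floor lies within the scatter); the step from compound 1 to compound 2 is a step that the two limits leave unreadable from compound 1 to compound 2.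

Compound 4 `Nc1ccc(S(=O)(=O)N2CCN(c3ncc(C(O)(C(F)(F)F)C(F)(F)F)cc3-c3cccc4[nH]ncc34)CC2)cn1` has not yet been measured. It differs from compound 3 only at one aromatic carbon: 1H-indazol-4-yl in place of 1-methyl-1H-pyrazol-4-yl on an aromatic carbon. Going by the values given here, no measured step in this set involves the 1H-indazol-4-yl group, so the only guide is that the same aromatic carbon carried the groups whose exchange gave the steps above, all small. The step from compound 3 to compound 4 is therefore expected to be a 1.3-fold higher number from compound 3 to compound 4 (0.12 log units; within the scatter), small and not clearly beyond the scatter. For compound 4 the expected value is 25 mL.min-1.g-1, estimated to lie between 12 mL.min-1.g-1 and 55 mL.min-1.g-1.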

Compound 4, intrinsic clearance in microsomes: 42 mL.min-1.g-1
For compound 4 the middle estimate is 1.7-fold (0.23 log units) below the measured one, and the stated range covers the measured number.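

Going by these compounds alone, at this aromatic carbon, two atoms from the ring nitrogen, the swap to 1H-indazol-4-yl gives the first step in this assay that is read as beyond the scatter, so the group held here can shift clearance: a 2.2-fold higher number from compound 3 to compound 4 (0.34 log units; beyond the scatter). Set against 2-cyclopropylethynyl the change is an at least 3.0-fold higher number from compound 1 to compound 4 (0.47 log units; beyond the scatter), and set against 3-hydroxy-3-methylbut-1-yn-1-yl it is an at least 3.0-fold higher number from compound 2 to compound 4 (0.47 log units; beyond the scatter). These two steps are only floors, as compound 1 and compound 2 each give a limit: the limit of < 14 mL.min-1.g-1 in this assay, at which 2 of the 4 values shown sit.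

The 1H-indazol-4-yl group brings a six-membered aromatic ring of carbon only and a hydrogen-bond donor together, and the compounds shown cannot tell which of the two goes with the higher number. A 1H-pyrazol-4-yl or a phenyl group on this carbon would separate them.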